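The source may report more compounds than this note shows. Statements on the series, on what has been measured and on what is new or still open speak of the compounds shown alone.

In a functional assay on DU-145 cells (Homo sapiens) for inhibition, read by trypan blue exclusion, with a stated time of 72 h (on this read-out higher numbers stand for weaker inhibition and lower numbers for stronger inhibition), compound 1 (`Cn1c(=O)c(S(=O)(=O)c2ccc(Cl)cc2)cc2cnc(Nc3ccc4[nH]ccc4c3)nc21`) gives 250 nM, compound 2 (`Cc1ccc(S(=O)(=O)c2cc3cnc(Nc4ccc5[nH]ccc5c4)nc3n(C)c2=O)cc1`) gives 750 nM and compound 3 (`Cn1c(=O)c(S(=O)(=O)Nc2ccc(F)cc2F)cc2cnc(Nc3ccc4[nH]ccc4c3)nc21`) gives 5000 nM, the highest of the three numbers. Compound 4 (`Cn1c(=O)c(S(=O)(=O)c2ccc(N)cc2F)cc2cnc(Nc3ccc4[nH]ccc4c3)nc21`) is still unmeasured. The change is 4-amino-2-fluorophenyl in place of (2,4-difluorophenyl)amino on a sulfonyl sulfur. The closest evidence runs the opposite way, with (2,4-difluorophenyl)amino entering: a 20-fold higher number from compound 1 to compound 3 (1.30 log units; beyond the scatter) (large) and a 6.7-fold higher number from compound 2 to compound 3 (0.82 log units; beyond the scatter) (modest). The methyl-for-chloro swap, a 3.0-fold higher number from compound 1 to compound 2 (0.48 log units; beyond the scatter), shows that the outcome also depends on the aromatic substituent. A sizeable move to a lower number is therefore expected in this assay. The estimated change is a 10-fold lower number from compound 3 to compound 4 (1.00 log units; beyond the scatter). Compound 4 is expected at about 500 nM, with an estimated range of 150 nM to 1800 nM.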

Compound 4, half-maximal inhibitory concentration: 8000 nM
Beside the measured number, compound 4's estimate is 16-fold (1.20 log units) below it; measured number above the stated range.
By their numbers in this assay, from the lowest: compound 1; then compound 2; then compounds 3 and 4 (each within the scatter of the next).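

In this assay the step of a 1.6-fold higher number from compound 3 to compound 4 (0.20 log units; within the scatter) shows that replacing the amino link with a direct aryl attachment on the sulfonyl sulfur does not, with 4-amino-2-fluorophenyl as the group, reach the lower numbers of compounds 1 and 2. At this position, the 4-methylphenyl and 4-chlorophenyl groups remain well ahead, with an 11-fold higher number from compound 2 to compound 4 (1.03 log units; beyond the scatter) and a 32-fold higher number from compound 1 to compound 4 (1.51 log units; beyond the scatter) as the steps. No supporting data bear on the reason for this result. Which of the amino and fluoro substituents goes with the higher number remains open. A 4-aminophenyl or 2-fluorophenyl group on the sulfonyl sulfur would separate the two.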